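The source may hold more compounds than are shown below. What is called first, only, known or untested is meant among the compounds shown, and "the series" means these compounds.

Among the measured compounds shown here, compound 3 `CN1CCC(c2ccc(Cl)cc2)C(C(=O)OCCCc2ccccc2)C1` stands at the top of the three numbers so far: in an assay on a subcellular fraction from brain for binding affinity to sodium-dependent dopamine transporter (Rattus norvegicus) (a higher number here means a weaker inhibitor, a lower number a stronger inhibitor), compound 3 gives 1420 nM. Compound 1 `CC(C)(C)O/N=C1\CN2CC[C@@H](c3ccc(Cl)cc3)C1C2` gives 725 nM in this assay, a gap from compound 3 that lies within the scatter. Compound 2 `Clc1ccc([C@@H]2CCN3C/C(=N\OCCCc4ccccc4)C2C3)cc1` gives 41 nM in this assay, a gap from compound 3 that lies well beyond the scatter. For the measured compounds named here, no pair of measured compounds differs in one place, so there is no direct guide for the next change. Compound 4 `CN1CCC(c2ccc(Cl)cc2)C(C(=O)OCCCCCc2ccccc2)C1` carries phenethyl in place of phenyl on a saturated chain carbon, three bonds along the chain from an oxygen next to a carbonyl group. With nothing measured along this line, the expected step of a 1.4-fold lower number from compound 3 to compound 4 (0.15 log units; within the scatter) is small and in no clear direction, not beyond the scatter. Compound 4 is estimated at 1000 nM in this assay, with a range from 300 nM to 4000 nM.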

Compound 4, inhibition constant: 53 nM
Beside the measured number, compound 4's estimate is 19-fold (1.28 log units) above it, outside the stated range (below it).
By their numbers in this assay, from the lowest: compounds 2 and 4 (each within the scatter of the next); then compounds 1 and 3 (each within the scatter of the next).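

Phenethyl in place of phenyl, on a saturated chain carbon, three bonds along the chain from an oxygen next to a carbonyl group, gives a 27-fold lower number from compound 3 to compound 4 (1.43 log units; beyond the scatter) in this assay. Among the compounds shown here, this is the first single-place step, and it shows that the number at this position depends strongly on chain length, with the same difference also reading as benzyl to 3-phenylpropyl. Nothing available accounts for the size of this step. A longer chain could extend this step or reverse it, and an amine within the chain remains an open replacement.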